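A few compounds are considered here, and "the series" means these few. Any claim that something is new, unique, unknown or untested is made for them only; others in the source may bear on it.

Working notes on the series. Three compounds share one core: compound 1 `CCNC(=O)Nc1nc2cc(-c3ccc(C(=O)O)nc3)cc(-c3ccccn3)c2s1`, compound 2 `CCNC(=O)Nc1nc2cc(-c3cnc(N4CCC(C(=O)O)CC4)nc3)cc(-c3ccccn3)c2s1` and compound 3 `CCNC(=O)Nc1nc2cc(-c3ccc(N4CCC(C)(C(=O)O)CC4)nc3)cc(-c3ccccn3)c2s1`. In a physicochemical assay for solubility, read by turbidimetry, in phosphate buffer, with a stated time of 24 h, at pH 7.4 (on this read-out lower numbers stand for lower solubility and higher numbers for higher solubility), compound 1 gives 50 ug/mL. In this assay compound 2 reaches only a limit, > 800 ug/mL. In this assay compound 3 likewise reaches only a limit, > 800 ug/mL. Compound 2 thus stands at the top of what is shown, since (the limit of > 800 ug/mL in this assay, at which 2 of the 3 values shown sit).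

Among the measured compounds shown here, the one measured step, an at least 16-fold higher number from compound 1 to compound 3 (1.20 log units; beyond the scatter), shows that exchanging a carboxy group on an aromatic carbon for a carboxy-bearing piperidine moves the read-out in this assay by a large amount upward, as far as the assay can report.

The unmeasured compound 4 `CCNC(=O)Nc1nc2cc(-c3cnc(N4CCCCC4(C)C(=O)O)nc3)cc(-c3ccccn3)c2s1` differs from compound 2 by 2-carboxy-2-methylpiperidin-1-yl in place of 4-carboxypiperidin-1-yl on an aromatic carbon. No measured pair isolates a shift of the carboxy group and methyl along the piperidine ring, so the change between compound 2 and compound 4 has no direct counterpart among the measured steps; the only bearing evidence is that both piperidine carboxylic acids shown, compound 2 and compound 3, sit at the limit, while compound 1 alone gives a number.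

A step of a number no higher from compound 2 to compound 4 (the limit leaves the size open) is therefore expected, that is, none beyond the scatter. Compound 4 is estimated at 800 ug/mL in this assay, within 250 ug/mL to 800 ug/mL, most likely again reported as a limit.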

Compound 4, solubility: 6.25 ug/mL
Beside the measured number, compound 4's estimate is 130-fold (2.11 log units) above it; the measured number lies below the stated range.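

In this assay, among the compounds shown here, the exchange of 4-carboxypiperidin-1-yl for 2-carboxy-2-methylpiperidin-1-yl, on an aromatic carbon between two ring nitrogen atoms, gives an at least 120-fold lower number from compound 2 to compound 4 (2.10 log units; beyond the scatter) and is the first large downward step. A carboxy-bearing piperidine at this position therefore does not by itself keep the read-out at the top: compound 2 and compound 3 suggested that it might, and compound 4 goes against that picture. The step has no fixed size, since compound 2 gives a limit and not a number: (the limit of > 800 ug/mL in this assay, at which 2 of the 4 values shown sit).

The change joins a new place for the carboxy group on the piperidine ring with an added methyl, and 2-carboxypiperidin-1-yl without the methyl, or 4-carboxy-4-methylpiperidin-1-yl on this same ring, would be needed to tell the two apart. Also open, on these data alone, is how the read-out responds at this position to a piperidine bearing an amine in place of the carboxylic acid.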